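Adding a Methyl to the Ring of Compound 1

This account rests on a few compounds, and the source may have more. Where it says the series, first, only, none or still open, it means among the compounds named here.

Compound 1 `CC(C(=O)NCc1cccc(Cl)c1)N1C(=O)CCC1=O` gives 82 mg/kg in a functional assay on the whole organism (strain Albino Swiss CD1) with Mus musculus as the target, in the maximal electroshock model; a higher number here means that more compound is needed for the effect, a lower number that less compound is needed.
Compound 2 `CC(C(=O)NCc1cccc(C(F)(F)F)c1)N1C(=O)CCC1=O` gives 92.4 mg/kg in this assay.
Compound 3 `CCC(C(=O)NCc1cccc(Cl)c1)N1C(=O)CCC1=O` gives 96.6 mg/kg in this assay.

Compound 1 has the lowest of the three numbers, yet the gaps are small: a 1.1-fold higher number from compound 1 to compound 2 (0.05 log units; within the scatter) and a 1.2-fold higher number from compound 1 to compound 3 (0.07 log units; within the scatter), so no order among the three can be claimed. Compound 4 `CC1CC(=O)N(C(C)C(=O)NCc2cccc(Cl)c2)C1=O` differs from compound 1 by methyl in place of hydrogen on a saturated ring carbon. Among the compounds with values here, no measured step makes exactly this change. The closest is the step to compound 3, which also enters a methyl on a saturated carbon and stayed within the scatter, as did the step to compound 2. On that basis, no step beyond the scatter is expected. Compound 4 is therefore expected to give about 85 mg/kg, in a range from 45 mg/kg to 170 mg/kg. This expectation means a 1.0-fold higher number from compound 1 to compound 4 (0.02 log units; within the scatter).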

Compound 4, dose for half-maximal effect: 90.3 mg/kg
Beside the measured number, compound 4's estimate is 1.1-fold (0.03 log units) below it; low and high end bracket the measured number.
By their numbers in this assay, from the lowest: compounds 1, 4, 2 and 3 (each within the scatter of the next).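

In this assay, methyl in place of hydrogen on a saturated ring carbon, two ring bonds from the ring nitrogen, gives a step within the scatter (a 1.1-fold higher number from compound 1 to compound 4 (0.04 log units; within the scatter)). Within the data shown here, the earlier compounds changed the aromatic ring and the chain, so this is the first sign that the five-membered ring of compound 1 can carry a small addition without a readable change in this assay. No measurements are available that could explain this result.

Going by these compounds, whether this ring carbon would tolerate something larger, such as a phenyl ring, or a group like an amine, remains open.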